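Undrawn stereocentre in the 2-carboxypiperidin-1-yl compounds

The compounds below may be only part of what the source reports. "The series", "measured", "known", "first", "only" and "open" are said of these compounds alone.

Measured in an ADME assay on NCM460 cells (Homo sapiens) for cytotoxicity, read by CCK-8 assay, with a stated time of 48 h (a higher number here means a weaker inhibitor, a lower number a stronger inhibitor), limits only:
compound 1 `COc1ccc(/C=C\c2cc(OC)c(OC)c(OC)c2)cc1OCc1ccc(CNC(C)(C)C(=O)O)cc1` at > 50000 nM (limit)
compound 2 `COc1ccc(/C=C\c2cc(OC)c(OC)c(OC)c2)cc1OCc1ccc(CN2CCCC[C@H]2C(=O)O)cc1` at > 50000 nM (limit)
compound 3 `COc1ccc(/C=C\c2cc(OC)c(OC)c(OC)c2)cc1OCc1ccc(CN2CCCC[C@@H]2C(=O)O)cc1` at > 50000 nM (limit)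

Compound 2 stands at > 50000 nM in this assay as a limit and not a number. The change to compound 4 `COc1ccc(/C=C\c2cc(OC)c(OC)c(OC)c2)cc1OCc1ccc(CN2CCCCC2C(=O)O)cc1` is the two compounds have the same atoms and bonds; at least one stereo element is drawn with a configuration in one of them and without one in the other: 1 of 2 stereo elements differ; a stereocentre at a saturated ring carbon is drawn S in compound 2 and without a configuration in compound 4 and nothing else. Within the data shown here, no step that bears on it has a readable size. The closest is a step that the two limits leave unreadable from compound 2 to compound 3 with the fact that compounds 2 and 3 differ only in the configuration as drawn as its only distinction, and a step that the two limits leave unreadable from compound 1 to compound 2 and a step that the two limits leave unreadable from compound 1 to compound 3 add no size. The whole record is the limit of > 50000 nM in this assay, at which 3 of the 3 values shown sit, for now. Given a step that the two limits leave unreadable from compound 2 to compound 3 as the sole comparison of configuration, the expected step that the limit leaves unreadable from compound 2 to compound 4 is none beyond the scatter in this assay and another limit is likely. For compound 4 the estimate is 60000 nM with an expected range from 40000 nM to 100000 nM at most.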

Compound 4, half-maximal inhibitory concentration: > 50000 nM
Compound 4: only a limit was reported (the forecaster's own chance of this, stated with the estimate: 92%); the middle value is on the limit's open side.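

In this assay, among these compounds, compound 4 gives > 50000 nM, a limit and not a number; no step between it and compound 1, compound 2 or compound 3 can be read. The compounds shown leave open whether the configuration at the saturated ring carbon of compound 2, compound 3 and compound 4 affects the value at all.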